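The source may hold more compounds than are shown below. What is called first, only, known or untested is meant among the compounds shown, and "the series" means these compounds.

In an ADME assay on liver for metabolic stability, with Liver microsome (Homo sapiens) as the target, read by LC-MS, using microsomes, with a stated time of 5 h (a lower number here means slower removal, a higher number faster removal of the compound), compound 1 `O[C@@]1(c2ccccn2)CC[C@@H](c2ccc(C(F)(F)F)cc2)C1` gives 150 mL/min/kg and compound 2 `O[C@]1(c2ccccn2)CC[C@@H](c2ccc(C(F)(F)F)cc2)C1` gives 383 mL/min/kg, the higher of the two numbers. Compound 3 `O[C@@]1(c2ccccn2)CC[C@H](c2ccc(C(F)(F)F)cc2)C1` is the next to be measured. Relative to compound 2, the change is the two compounds have the same atoms and bonds and differ only in configuration as drawn: 2 of 2 stereo elements differ (all stereocentres are inverted: mirror images); a stereocentre at a saturated ring carbon is drawn R in compound 2 and S in compound 3; a stereocentre at a saturated ring carbon is drawn R in compound 2 and S in compound 3, so all stereocentres are inverted and the two compounds are mirror images. Among the compounds with values here, only one measured step bears on this: a 2.6-fold higher number from compound 1 to compound 2 (0.41 log units; beyond the scatter), a modest step that arises from the fact that compounds 1 and 2 differ only in the configuration as drawn. With that single step as a guide, a change in configuration is expected to move the number by a similar modest size. The direction is expected to be downward, though weakly so, because compound 2 sits at the top of a two-compound range at 383 mL/min/kg. The expected step is a 1.7-fold lower number from compound 2 to compound 3 (0.24 log units; within the scatter). Compound 3 is estimated at 220 mL/min/kg, with an expected range from 100 mL/min/kg to 450 mL/min/kg.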

Compound 3, clearance: 400 mL/min/kg
Compound 3: middle estimate off by 1.8-fold (0.26 log units), on the low side; measured number inside the range.
By their numbers in this assay, from the lowest: compound 1; then compounds 2 and 3 (each within the scatter of the next).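

In this assay the mirror-image pair shows no separation, with a 1.0-fold higher number from compound 2 to compound 3 (0.02 log units; within the scatter), so inverting both stereocentres together gives no readable difference. Inverting only the stereocentre drawn R in compound 1 gives a 2.7-fold higher number from compound 1 to compound 3 (0.43 log units; beyond the scatter), the same direction as the inversion of the stereocentre drawn S in compound 1, a 2.6-fold higher number from compound 1 to compound 2 (0.41 log units; beyond the scatter). Compound 1 therefore stands apart from compounds 2 and 3 by either single inversion, and with atoms and bonds shared, this difference rests on configuration alone: the fact that compounds 1 and 3 differ only in the configuration as drawn.

The mirror image of compound 1 lies outside the compounds shown, so it remains open whether its mirror image would also give the lower number. Also open, as far as these compounds go, is whether the gap between configurations persists with an amine or a carboxylic acid in place of the hydroxy group.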